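Chloro on the Core: Expected Cytotoxicity of Compound 4

A few compounds are considered here, and "the series" means these few. Any claim that something is new, unique, unknown or untested is made for them only; others in the source may bear on it.

Three compounds sharing a common core have been examined in a toxicity assay on MDCK cells (Canis lupus familiaris) for cytotoxicity, read by crystal violet staining, with a stated time of 48 h; on this read-out higher numbers stand for lower toxicity in this test and lower numbers for higher toxicity in this test. Compound 1 `COc1ccc(C(C)N(Cc2ccc(C(C)(C)C)cc2)Cc2cc3cc(C)ccc3[nH]c2=O)cc1` carries a 4-methoxyphenyl group on the ethyl arm. In this assay compound 1 gives > 5000 nM, which is a limit of the assay rather than a number. Compound 2 `COc1ccc(C(C)N(Cc2ccc(C(C)(C)C)cc2)Cc2cc3cc(C)ccc3[nH]c2=O)cc1Cl` differs from compound 1 by chloro in place of hydrogen on an aromatic carbon. In this assay compound 2 gives > 10000 nM, again a limit. The step that the two limits leave unreadable from compound 1 to compound 2 cannot be sized, because both values sit at limits, as the limit of > 10000 nM in this assay, at which 2 of the 3 values shown sit, and the limit of > 5000 nM in this assay, at which 1 of the 3 values shown sits, show.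

Compound 3 `COc1ccc([C@H](C)N(Cc2ccc(OC(F)(F)F)cc2)Cc2cc3ccccc3[nH]c2=O)cc1` has a different core from compound 1; the difference between the two cores is not broken down here. In this assay compound 3 gives > 10000 nM, which is a limit.

Compound 4 `COc1ccc([C@H](C)N(Cc2ccc(OC(F)(F)F)cc2)Cc2cc3cc(Cl)ccc3[nH]c2=O)cc1` has not yet been measured. It differs from compound 3 by chloro in place of hydrogen on an aromatic carbon. This is the same kind of change as that from compound 1 to compound 2, but the surroundings differ: in compound 2 the chloro sits ortho to a methoxy group and meta to a large group, whereas in compound 4 it sits on a ring that is part of a fused system of two rings, meta and para to a fused ring.

Since compound 3 gives > 10000 nM and the chloro step between compound 1 and compound 2 stayed within limits, compound 4 is expected to remain at or beyond the limit, with an estimated 15000 nM and an expected step that the limit leaves unreadable from compound 3 to compound 4.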

Compound 4, half-maximal cytotoxic concentration: > 10000 nM
Compound 4 ended at the assay's limit; the forecaster's own chance of this, stated with the estimate: 75%; the middle value is on the limit's open side.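

In this assay compound 4 gives > 10000 nM, which is a limit of the assay and not a number. No size can be read for the chloro step between compound 3 and compound 4, because both compounds sit at the same limit: the limit of > 10000 nM in this assay, at which 3 of the 4 values shown sit.

The compounds shown leave open at what concentration any of them would become toxic to these cells, and whether chloro in place of hydrogen changes that concentration at all.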